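The compounds below may be only part of what the source reports. "The series", "measured", "known", "first", "only" and "open" are said of these compounds alone.

Of the compounds shown here, three built on a shared core have been tested in an ADME assay on HEK293 cells (Homo sapiens) for cytotoxicity, read by sulforhodamine B assay, with a stated time of 48 h, tested at 10 uM; on this read-out higher numbers stand for more inhibition at the one concentration tested (going by the name of the read-out) and lower numbers for less inhibition. Compound 1 `COc1nc2ccc(Br)cc2cc1C(c1ccccc1)n1cc(CCCCCO)nn1` gives 7.96%. Compound 2 `CCCCCCCCc1cn(C(c2ccccc2)c2cc3cc(Br)ccc3nc2OC)nn1` gives 14.6%. Compound 3 `COc1nc2ccc(Br)cc2cc1C(c1ccccc1)n1cc(CCCO)nn1` gives 27.4%, the highest of the three numbers: the step of a number 12.8 percentage points higher from compound 2 to compound 3 (beyond the scatter) lies beyond the scatter, as does the step of a number 19.4 percentage points higher from compound 1 to compound 3 (beyond the scatter). The step of a number 6.6 percentage points higher from compound 1 to compound 2 (within the scatter) is within the scatter, so no order between compound 1 and compound 2 can be read.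

Compound 4 `COc1nc2ccc(Br)cc2cc1C(c1ccccc1)n1cc(CO)nn1` has not yet been measured. Relative to compound 3 the change is hydroxy in place of 2-hydroxyethyl on a saturated chain carbon bound to an aromatic carbon. The closest parallel is the step of a number 19.4 percentage points higher from compound 1 to compound 3 (beyond the scatter), the same exchange of hydroxy for 2-hydroxyethyl placed one bond further out along the chain, where the number rose modestly. The step of a number 12.8 percentage points higher from compound 2 to compound 3 (beyond the scatter) also rose when hydroxy replaced a longer chain, though that pair is less alike. For the measured compounds named here, with only one step of the same kind to lean on, a small rise or no change beyond the scatter is expected. Compound 4 is therefore expected to give about 32%, with a range from 12% to 52%. This estimate amounts to a step of a number 4.6 percentage points higher from compound 3 to compound 4 (within the scatter).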

Compound 4, a percentage reported as inhibition, at one concentration (the size of the read-out at that concentration, not a potency): 11.5%
Compound 4: the middle estimate sits 20.5 percentage points above what was measured; the measured number lies below the stated range.
By their numbers in this assay, from the lowest: compounds 1, 4 and 2 (each within the scatter of the next); then compound 3.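

In this assay, the exchange of 2-hydroxyethyl for hydroxy does not act the same way at every chain length: taking 3-hydroxypropyl down to hydroxymethyl gives a number 15.9 percentage points lower from compound 3 to compound 4 (beyond the scatter), whereas the same exchange one bond further out gave a number 19.4 percentage points higher from compound 1 to compound 3 (beyond the scatter), the opposite direction. The short hydroxymethyl chain cannot be told apart from the longer chains, with a number 3.1 percentage points lower from compound 2 to compound 4 (within the scatter) and a number 3.5 percentage points higher from compound 1 to compound 4 (within the scatter), so among these four compounds only compound 3, with its 3-hydroxypropyl, stands clear of the scatter from all the others. Nothing measured on these compounds offers an explanation for this reversal.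

Going by these compounds, what a 2-hydroxyethyl or a 4-hydroxybutyl chain would give at this place remains open, so it cannot yet be said whether compound 3 marks a narrow rise at one chain length or part of a broader one. Also open, on these data alone, is whether an amine or a carboxylic acid in place of the hydroxy of compound 3 would keep its number or bring it back towards those of the other three compounds.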